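The source may report more compounds than this note shows. Statements on the series, on what has been measured and on what is new or still open speak of the compounds shown alone.

Compound 3 `COc1ccc(N(C)c2nc(C)nc3ccccc23)cc1OCCCCC[Se]C#N` stands at the high end of the three numbers recorded so far. In a functional assay on LoVo cells (Homo sapiens) for inhibition, read by MTT assay, with a stated time of 48 h (a higher number here means a weaker inhibitor, a lower number a stronger inhibitor), compound 3 gives 5210 nM. The other two compounds sit far below it: compound 1 `Cc1nc(N(C)c2ccc([Se]C#N)c(Cl)c2)c2ccccc2n1` gives 12 nM in this assay, and compound 2 `C[Se]c1ccc(N(C)c2nc(C)nc3ccccc23)cc1C` gives 9 nM in this assay. Both gaps from compound 3 lie well beyond the scatter of repeated measurements, so compound 3 is the weakest inhibitor of the three as measured.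

Compound 4 `COc1ccc(N(C)c2nc(C)nc3ccccc23)cc1[Se]C` has not yet been measured. It differs from compound 3 in one place: a group of 2 heavy atoms (1 carbon, 1 selenium; no ring) in place of a group of 9 heavy atoms (6 carbon, 1 nitrogen, 1 oxygen, 1 selenium; no ring), on an aromatic carbon The entering group sits on an aromatic carbon of a six-membered aromatic ring of carbon only, ortho to a methoxy group and meta to a large group. Within the data shown here, no step between two measured compounds covers this exact change, so the expectation rests on the three values themselves. Compound 2, whose selenium is carried as a methylseleno group directly on the ring, gives 9 nM, whereas compound 3 with its long chain gives 5210 nM. Compound 4 is therefore expected to move toward the lower numbers, the estimated step of a 170-fold lower number from compound 3 to compound 4 (2.24 log units; beyond the scatter) being large and downward, well beyond the scatter. In this assay compound 4 is estimated at 30 nM, with a range from 5 nM to 200 nM.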

Compound 4, half-maximal inhibitory concentration: 3 nM
Compound 4: the middle estimate sits 10-fold (1.00 log units) above what was measured; measured number outside the range, below it.
By their numbers in this assay, from the lowest: compound 4; then compounds 2 and 1 (each within the scatter of the next); then compound 3.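

In this assay, placing the group of 2 heavy atoms in place of the group of 9 heavy atoms gives a 1700-fold lower number from compound 3 to compound 4 (3.24 log units; beyond the scatter), the only step shown between two compounds that differ in one place. It shows that the high number of compound 3 depends on what sits on this aromatic carbon, ortho to a methoxy group and meta to a large group, since everything else in the pair is the same and compound 4 gives 3 nM with the methoxy group retained. The whole group changes in this single step, so the pair does not separate the contributions of the chain, its oxygen and its nitrile, and nothing measured here accounts for the size of the step.

The compounds shown leave open whether a shorter alkoxy chain ending in the same nitrile would give a low number at this carbon or a number nearer that of compound 3. They also leave open whether a methylthio group or a plain methyl group on this carbon would match the methylseleno group of compound 4, which would indicate how much the selenium itself matters here.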